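Swapping the Amine Side Group on a Fluorinated Core

A few compounds are considered here, and "the series" means these few. Any claim that something is new, unique, unknown or untested is made for them only; others in the source may bear on it.

Compound 1 `CCNCC1CCN(c2c(F)cc3c(=O)c(C(=O)O)cn(C4CC4)c3c2OC)C1` in a functional assay on V79 cells (Cricetulus griseus) for cytotoxicity, read by colony formation (a higher number here means a weaker inhibitor, a lower number a stronger inhibitor), gives 22 ug/mL; 22 ug/mL (2 entries).
Compound 2 `CCNCC1CCN(c2nc3c(cc2F)c(=O)c(C(=O)O)cn3C2CC2)C1` in this assay gives 160 ug/mL.

Going by the values given here, for compound 2 this is the only number available; a further measurement of it gave no single value. The two compounds differ in more than one place, so their values are simply set side by side. Compound 3 `O=C(O)c1cn(C2CC2)c2nc(N3CCNCC3)c(F)cc2c1=O` keeps the core of compound 2 and differs from it by piperazin-1-yl in place of 3-((ethylamino)methyl)pyrrolidin-1-yl on an aromatic carbon. The piperazin-1-yl enters where the 3-((ethylamino)methyl)pyrrolidin-1-yl leaves, on an aromatic carbon next to the ring nitrogen and ortho to a fluoro group. Among the compounds with values here, no measured pair shows this exact change, so the expectation rests on compound 2 alone. The expected step is a 1.6-fold higher number from compound 2 to compound 3 (0.19 log units; within the scatter), a move toward weaker inhibition that should exceed the usual scatter. Compound 3 is therefore estimated at 250 ug/mL, with a range from 120 ug/mL to 500 ug/mL.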

Compound 3, half-maximal inhibitory concentration: 120 ug/mL
For compound 3 the middle estimate is 2.1-fold (0.32 log units) above the measured one; low and high end bracket the measured number.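

In this assay, placing piperazin-1-yl in place of 3-((ethylamino)methyl)pyrrolidin-1-yl on the aromatic carbon next to the ring nitrogen gives a 1.3-fold lower number from compound 2 to compound 3 (0.12 log units; within the scatter), so this exchange does not separate the two compounds. This first one-place comparison shows that a six-membered non-aromatic ring with 2 hetero atoms can replace a five-membered one with 1 hetero atom and its side chain without a change beyond the scatter. Nothing available explains this result, which stands as an observation only.

As far as these compounds go, it remains open whether a morpholin-4-yl or 4-methylpiperazin-1-yl group on this same carbon would shift the number beyond the scatter. From the compounds shown here alone, it is equally open whether piperazin-1-yl would behave the same way on the core of compound 1.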